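The source may hold more compounds than are shown below. What is called first, only, known or untested is meant among the compounds shown, and "the series" means these compounds.

Two measured compounds share one core and differ only in the group on a carbonyl carbon. Compound 1 `CC(C)NC(=O)N1CCN(C(=S)SCc2cn(Cc3ccccc3F)nn2)CC1` carries an isopropylamino group there, and in a functional assay on MGC-803 cells (Homo sapiens) for cytotoxicity, read by MTT assay, with a stated time of 72 h (a higher number here means a weaker inhibitor, a lower number a stronger inhibitor), compound 1 gives 1620 nM. Among the measured compounds shown here, compound 2 `CCN(C)C(=O)N1CCN(C(=S)SCc2cn(Cc3ccccc3F)nn2)CC1` carries an ethyl(methyl)amino group in the same place, and in this assay compound 2 gives 5860 nM, the highest of the two numbers; the step of a 3.6-fold higher number from compound 1 to compound 2 (0.56 log units; beyond the scatter) is the only measured step so far. Compound 3 `CC(C)(C)NC(=O)N1CCN(C(=S)SCc2cn(Cc3ccccc3F)nn2)CC1` is not yet measured. It differs from compound 2 as follows: (tert-butyl)amino in place of ethyl(methyl)amino on a carbonyl carbon. This change brings back the hydrogen-bond donor that compound 2 lacks, so the step of a 3.6-fold higher number from compound 1 to compound 2 (0.56 log units; beyond the scatter) bears on it most directly and points to a move back in the other direction. On that basis compound 3 is expected to show a step of a 3.3-fold lower number from compound 2 to compound 3 (0.51 log units; beyond the scatter) in this assay. The estimate for compound 3 in this assay is 1800 nM, with a range from 700 nM to 5000 nM.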

Compound 3, half-maximal inhibitory concentration: 40700 nM
The estimate for compound 3 lay 23-fold (1.35 log units) below the measured number; the measured number lies above the stated range.
By their numbers in this assay, from the lowest: compound 1; then compound 2; then compound 3.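

Having a hydrogen-bond donor on this carbonyl carbon is not enough to keep the number low in this assay: (tert-butyl)amino carries one and ethyl(methyl)amino does not, yet the change gives a 6.9-fold higher number from compound 2 to compound 3 (0.84 log units; beyond the scatter) and moves the number further from that of compound 1. The position is also highly sensitive to a small change in the group, since one added methyl on the saturated chain carbon of isopropylamino gives a 25-fold higher number from compound 1 to compound 3 (1.40 log units; beyond the scatter), the largest step among these compounds. No measurement shown here explains these differences.

On these data alone, it remains open how ethylamino, propylamino or cyclopropylamino would behave on this carbonyl carbon in this assay. As far as these compounds go, whether the same order of compounds holds in other cell types also remains open.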